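From 1,2-diacetoxyethyl to 1,2-dihydroxyethyl on compound 2

The compounds below may be only part of what the source reports. "The series", "measured", "known", "first", "only" and "open" are said of these compounds alone.

Compound 1 `CC(=O)OC[C@@H](OC(C)=O)[C@H]1O[C@@H](n2cnc3c(Cl)ncnc32)[C@H](OC(C)=O)[C@@H]1OC(C)=O`: > 100000 nM (a limit, not a number)
Compound 2 `CC(=O)OC[C@@H](OC(C)=O)[C@H]1O[C@@H](n2cnc3c(Cl)nc(Cl)nc32)[C@H](OC(C)=O)[C@@H]1OC(C)=O`: 24200 nM

Both compounds were tested in a functional assay on HeLa cells (Homo sapiens), read by colorimetric assay, with a stated time of 48 h; a lower number here means a stronger inhibitor, a higher number a weaker inhibitor. Going by the values given here, compound 2 stands alone so far as the only one with a true number, since the other result is a limit. Among the compounds with values here, the one measured step is an at least 4.1-fold lower number from compound 1 to compound 2 (0.61 log units; beyond the scatter), made by chloro in place of hydrogen on an aromatic carbon.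

Compound 3 `CC(=O)O[C@H]1[C@@H](OC(C)=O)[C@H](n2cnc3c(Cl)nc(Cl)nc32)O[C@@H]1[C@H](O)CO` keeps that chloro and changes elsewhere: 1,2-dihydroxyethyl in place of 1,2-diacetoxyethyl on a saturated ring carbon. Here 1,2-dihydroxyethyl stands in place of 1,2-diacetoxyethyl on a saturated ring carbon. The measured step lies at a different place, so it gives only a loose idea of how far one change can move the number, and no measurement tests this site directly. A modest move towards a higher number is expected, though this is a cautious guess from the high value of compound 2 at 24200 nM. The estimated change is a 1.7-fold higher number from compound 2 to compound 3 (0.22 log units; within the scatter). Compound 3 is expected to give about 40000 nM, with an estimated range from 12000 nM to 100000 nM. The result could also end at the limit of > 100000 nM in this assay, at which 1 of the 2 values shown sits.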

Compound 3, half-maximal inhibitory concentration: 36300 nM
Estimate against measurement, compound 3: 1.1-fold (0.04 log units) above, within the range that was stated.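

Going by these compounds alone, replacing 1,2-diacetoxyethyl with 1,2-dihydroxyethyl gives a 1.5-fold higher number from compound 2 to compound 3 (0.18 log units; within the scatter) in this assay, the first measurement that tests this position directly. The change is a large one on paper: a group of 10 heavy atoms with 0 hydrogen-bond donors gives way to one of 4 heavy atoms with 2 hydrogen-bond donors, yet compound 2 and compound 3 cannot be told apart in this assay. So at this level of activity, with the second chloro kept in place, the read-out does not register a difference between these two groups on this saturated ring carbon, and compound 3 still gives a true number rather than a limit.

The result for compound 1 is a limit and not a number, so the same change on that compound could not be expected to give a readable step if its value stayed there: the limit of > 100000 nM in this assay, at which 1 of the 3 values shown sits. Still open, as far as these compounds go, is how this ring carbon responds to a group of another kind, such as an amine, a carboxylic acid or a longer chain, and whether any such group would move the number beyond the scatter.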